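The source may hold more compounds than are shown below. What is called first, only, known or untested is meant among the compounds shown, and "the series" means these compounds.

Compound 1, `COc1ccc(S(=O)(=O)c2cnc3cc(F)ccc3c2-c2ccc(Cl)cc2)cc1`, and compound 2, `COc1ccc(S(=O)(=O)c2cnc3cc(F)ccc3c2-c2ccc(F)cc2)cc1`, share one core and differ in a single group. In an ADME assay on microsomes from liver (Homo sapiens) for metabolic stability, tested at 2.5 uM (a lower number here means slower removal, a higher number faster removal of the compound), compound 1 gives 1.28 mL/min, the lowest of the two numbers; compound 2 gives 1.71 mL/min, which lies within the scatter of compound 1, as the step of a 1.3-fold higher number from compound 1 to compound 2 (0.13 log units; within the scatter) shows.

Compound 3, `O=S(=O)(c1ccc(F)cc1)c1cnc2cc(F)ccc2c1-c1ccc(Cl)cc1`, is not yet measured. It differs from compound 1 as follows: fluoro in place of methoxy on an aromatic carbon.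

Among the measured compounds shown here, no measured step touches that group or that position; the only step available, a 1.3-fold higher number from compound 1 to compound 2 (0.13 log units; within the scatter), concerns a different ring and stays within the scatter. The data therefore give no ground to expect a step beyond the scatter in this assay in either direction. Compound 3 is expected to give 1.3 mL/min, with a range from 0.6 mL/min to 2.8 mL/min, which is the expected step of a 1.0-fold higher number from compound 1 to compound 3 (0.01 log units; within the scatter).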

Compound 3, intrinsic clearance in a liver preparation (reported as CLH), per the amount of preparation that the assay uses: 1.23 mL/min
Compound 3: middle estimate off by 1.1-fold (0.02 log units), on the high side, within the range that was stated.
By their numbers in this assay, from the lowest: compounds 3, 1 and 2 (each within the scatter of the next).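

In this assay, among the compounds shown here, exchanging 4-methoxyphenyl for 4-fluorophenyl gives a 1.0-fold lower number from compound 1 to compound 3 (0.02 log units; within the scatter), the first reading at this position, para to a large group, as the earlier step changed only the chloro on the other ring. In this one pair, the methoxy can therefore be replaced by fluoro, with the loss of its carbon and oxygen, without moving the clearance number beyond the usual scatter. Nothing measured here explains why the number stays put, as no supporting data on the cause are available.

From the compounds shown here alone, only methoxy and fluoro have been seen at this position, so it remains open whether an amine, a carboxylic acid or a longer alkoxy chain would leave the number equally unmoved. Going by these compounds, it is also open whether the same exchange would behave alike on a compound carrying fluoro instead of chloro on the other ring.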